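The compounds below may be only part of what the source reports. "The series", "measured", "known", "first", "only" and "open" are said of these compounds alone.

Of the compounds shown here, three of one series have so far been measured in a physicochemical assay for solubility, in simulated intestinal fluid; a higher number here means a more soluble compound, a lower number a less soluble compound. Compound 1 `Cc1nc(C)n(CC(=O)N2CCN(c3sc(C(F)(F)F)nc3-c3nc4c(F)cccc4[nH]3)C[C@H]2C)n1` gives 750 ug/mL in this assay. Compound 2 `Cc1nn(CC(=O)N2CCN(c3sc(C(F)(F)F)nc3-c3nc4ccccc4[nH]3)C[C@H]2C)cc1CN(C)C` gives 645 ug/mL in this assay, and compound 1 and compound 2 sit within the scatter of each other. Compound 3 `Cc1nc(C)n(CC(=O)N2CCN(c3sc(C(F)(F)F)nc3-c3nc4ccc(C5CCOCC5)cc4[nH]3)C[C@H]2C)n1` is reported only as a limit of this assay, > 1000 ug/mL, so no number is known for it. The evidence on this is the limit of > 1000 ug/mL in this assay, at which 1 of the 3 values shown sits. Among the compounds with values here, no two of the measured compounds differ in a single place, so no step between them can be followed.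

Compound 4 `Cc1nc(C)n(CC(=O)N2CCN(c3sc(C(F)(F)F)nc3-c3nc4ccc(C5CCN(C)CC5)cc4[nH]3)C[C@H]2C)n1` has not yet been measured in this assay. The change from compound 3 to compound 4 is 1-methylpiperidin-4-yl in place of oxan-4-yl on an aromatic carbon. The expectation for compound 4 rests on compound 3, whose result is the limit > 1000 ug/mL. A step no larger than the scatter is expected in this assay from compound 3 to compound 4, a step that the limit leaves unreadable from compound 3 to compound 4, and compound 4 is likely to be reported again as a limit. Compound 4 is estimated to give 1500 ug/mL in this assay, between 800 ug/mL and 3000 ug/mL.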

Compound 4, solubility: > 1020 ug/mL
Compound 4 gave a limit, no number; the forecaster's own chance of this, stated with the estimate: 80%; the middle value does not contradict the limit.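

Within the data shown here, compound 3 and compound 4 are both reported in this assay only as limits, so no step between them can be read. The compounds shown leave open what number either compound would give, and whether 1-methylpiperidin-4-yl in place of oxan-4-yl makes any difference.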